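Swapping a methoxyphenyl for a chlorophenyl on the hydrazone

The source may hold more compounds than are shown below. What is called first, only, known or untested is meant among the compounds shown, and "the series" means these compounds.

Of the compounds shown here, three sharing one core have been measured in a functional assay on HCT-116 cells (Homo sapiens) for antiproliferative activity, read by MTT assay; a higher number here means a weaker inhibitor, a lower number a stronger inhibitor. Compound 1 `Cn1c(=O)c(=O)n(C2CCCC2)c2nc(N/N=C/c3ccc(Cl)cc3)ncc21` gives 9810 nM. Compound 2 `COc1cccc(/C=N/Nc2ncc3c(n2)n(C2CCCC2)c(=O)c(=O)n3C)c1` gives 45800 nM. Compound 3 `Cn1c(=O)c(=O)n(C2CCCC2)c2nc(N/N=C/c3ccc(F)cc3F)ncc21` gives 19800 nM. Compound 2 thus stands at the highest number of the three, the weakest of this small set: a 4.7-fold higher number from compound 1 to compound 2 (0.67 log units; beyond the scatter), and a 2.3-fold lower number from compound 2 to compound 3 (0.36 log units; beyond the scatter). Compounds 1 and 3 are close to each other, since a 2.0-fold higher number from compound 1 to compound 3 (0.30 log units; within the scatter).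

Compound 4 `Cn1c(=O)c(=O)n(C2CCCC2)c2nc(N/N=C/c3ccccc3Cl)ncc21` is not yet measured. It differs from compound 2 in one place: 2-chlorophenyl in place of 3-methoxyphenyl on a carbon with a double bond to nitrogen. Among the measured compounds shown here, two measured steps bear on this change, as each replaces an aryl carrying a methoxy group with an aryl carrying one or two halogens, or the reverse: the step from compound 1 to compound 2 was modest and upward, and the step from compound 2 to compound 3 was modest and downward. Both point the same way for compound 4, so a modest downward step in this assay is expected, landing near the halogenated compounds 1 and 3. Compound 4 is therefore estimated at 15000 nM, with a range from 5000 nM to 45000 nM, meaning an expected step of a 3.1-fold lower number from compound 2 to compound 4 (0.48 log units; beyond the scatter).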

Compound 4, half-maximal inhibitory concentration: 14000 nM
For compound 4 the middle estimate is 1.1-fold (0.03 log units) above the measured one; the range from low to high includes it.
By their numbers in this assay, from the lowest: compounds 1, 4 and 3 (each within the scatter of the next); then compound 2.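

With compound 4 a second chlorophenyl joins the set, and replacing 4-chlorophenyl with 2-chlorophenyl gives a 1.4-fold higher number from compound 1 to compound 4 (0.15 log units; within the scatter) in this assay, so this assay does not tell these two placements of the chlorine apart. Replacing 2,4-difluorophenyl with 2-chlorophenyl likewise gives a 1.4-fold lower number from compound 3 to compound 4 (0.15 log units; within the scatter), whereas replacing 3-methoxyphenyl with 2-chlorophenyl gives a 3.3-fold lower number from compound 2 to compound 4 (0.51 log units; beyond the scatter), which leaves the three halogen-bearing compounds 1, 3 and 4 together and compound 2 apart from each of them as the weakest of the four. Nothing given here explains why the aryl groups on this carbon with a double bond to nitrogen fall into these two groups.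

Compound 2 differs from the others both in carrying a methoxy group and in where that group sits on the ring, so a 3-chlorophenyl or a 2-methoxyphenyl would be needed to separate the two. As far as these compounds go, how this position responds to a phenyl ring bearing an amine or a carboxylic acid, or to a longer chain in place of the aryl ring, also remains open.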